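Hydroxyethyl against methoxyethyl in a liver-cell cytotoxicity series

The source may hold more compounds than are shown below. What is called first, only, known or untested is meant among the compounds shown, and "the series" means these compounds.

Compound 1 `COc1cc(/C=C/C(=O)/C=C(/C=C/c2ccc(O)c(OC)c2)NCCO)ccc1O` and compound 3 `COCCNC(=C\C(=O)/C=C/c1ccc(O)c(OC)c1)/C=C/c1ccc(O)c(OC)c1` share one core; compound 2 `COCCNC(=C\C(=O)/C=C/c1ccc(O)cc1)/C=C/c1ccc(O)cc1` and the unmeasured compound 4 `O=C(/C=C(/C=C/c1ccc(O)cc1)NCCO)/C=C/c1ccc(O)cc1` share another. In a functional assay on HepG2 cells (Homo sapiens) for cytotoxicity, read by MTT assay, with a stated time of 48 h (on this read-out higher numbers stand for weaker inhibition and lower numbers for stronger inhibition), compound 1 gives only a limit of the assay, > 100000 nM. In this assay compound 3 likewise gives only a limit, > 100000 nM. In this assay, among the measured compounds shown here, compound 2 gives 63300 nM, the single number in the set. The change hydrogen in place of methyl on an oxygen on a saturated carbon makes a step that the two limits leave unreadable from compound 3 to compound 1, as the limit of > 100000 nM in this assay, at which 2 of the 3 values shown sit, covers both ends. The same change, (hydrogen in place of methyl on an oxygen on a saturated carbon), at a place described in the same words, leads from compound 2 to compound 4; the difference between the cores of compound 2 and compound 3 is not broken down here. Because compound 2 gives 63300 nM and the earlier step is unreadable, the step of a 1.3-fold higher number from compound 2 to compound 4 (0.10 log units; within the scatter) is expected to be small. Compound 4 is estimated at 80000 nM, between 35000 nM and 200000 nM.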

Compound 4, half-maximal inhibitory concentration: 48400 nM
Compound 4: the middle estimate sits 1.7-fold (0.22 log units) above what was measured; low and high end bracket the measured number.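

In this assay, the change from 2-methoxyethyl to 2-hydroxyethyl on the core of compound 2 gives a 1.3-fold lower number from compound 2 to compound 4 (0.12 log units; within the scatter), so on this core the change makes no difference that can be told from scatter. On the other core the same change cannot be read, because compound 3 and compound 1 both sit at a limit of the assay: the limit of > 100000 nM in this assay, at which 2 of the 4 values shown sit.

Carrying the change from one core to the other is therefore neither supported nor contradicted, since only one readable step exists.

Open, from the compounds shown here alone, is what an amine or a carboxylic acid in place of the hydroxy would do on either core. Also open, going by these compounds, is whether a longer chain would move the read-out beyond the scatter.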